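The source may report more compounds than this note shows. Statements on the series, on what has been measured and on what is new or still open speak of the compounds shown alone.

Measured so far:
compound 1 `CCCCn1nc2ccccc2c1OC` — 910 nM
compound 2 `CCCCCCCCn1nc2ccccc2c1OC` — > 10000 nM
compound 3 `CCCCn1[nH]c2ccccc2c1=O` — 792 nM

In an assay on isolated protein (urine) for inhibition of Myeloperoxidase (Homo sapiens), read by spectrophotometry (on this read-out higher numbers stand for weaker inhibition and lower numbers for stronger inhibition), compound 1 gives 910 nM. Compound 2 gives no number, only a limit, > 10000 nM. The step of an at least 10-fold higher number from compound 1 to compound 2 (1.04 log units; beyond the scatter) is large, which rests on compound 2 sitting at the limit of > 10000 nM in this assay, at which 1 of the 3 values shown sits. Compound 3 gives 792 nM, within the scatter of compound 1. The difference between the core of compound 1 and the core of compound 3 is not broken down here.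

Compound 4 `CCCCCCCCn1[nH]c2ccccc2c1=O` is not yet measured. It differs from compound 3 by butyl in place of hydrogen on a saturated chain carbon, four bonds along the chain from an aromatic nitrogen, the same change as butyl in place of hydrogen on a saturated chain carbon, four bonds along the chain from an aromatic nitrogen. The step expected from compound 3 to compound 4 is a 13-fold higher number from compound 3 to compound 4 (1.10 log units; beyond the scatter), resting on the measured step of an at least 10-fold higher number from compound 1 to compound 2 (1.04 log units; beyond the scatter). For compound 4 the estimated value in this assay is 10000 nM, expected between 4000 nM and 30000 nM, with a fair chance that only a limit is reported.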

Compound 4, half-maximal inhibitory concentration: > 10000 nM
Compound 4 was reported as a limit; the forecaster's own chance of this, stated with the estimate: 60%; the middle value lies on the limit itself.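

Butyl in place of hydrogen on a saturated chain carbon, four bonds along the chain from an aromatic nitrogen, gives an at least 12-fold higher number from compound 3 to compound 4 (1.10 log units; beyond the scatter) in this assay on the core of compound 3, so the change goes the same way on both cores shown. Compound 4 gives only a limit, > 10000 nM and no number. The direction therefore carries from one core to the other, but the true size of the step on either core is not shown, nor is any difference between the cores: the same change on two cores in this assay, an at least 10-fold higher number (1.04 log units; beyond the scatter) from compound 1 to compound 2 and an at least 12-fold higher number (1.10 log units; beyond the scatter) from compound 3 to compound 4; the limit leaves it open whether they differ

Open, from the compounds shown here alone, is how a pentyl or hexyl chain reads on either core. Also open, going by these compounds, is whether a chain ending in an amine or a carboxylic acid reads like the plain chains.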